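Swapping the aryloxy tail for an isopropyl amide

The source may hold more compounds than are shown below. What is called first, only, known or untested is meant among the compounds shown, and "the series" means these compounds.

Measured so far in an assay for inhibition of inositol hexakisphosphate kinase 2 (Homo sapiens), read by colorimetric assay, coupled enzyme assay and malachite green, with a stated time of 120 min, in the presence of a further agent that is not named here; a lower number here means a stronger inhibitor, a higher number a weaker inhibitor:
compound 1 `O=C(O)c1ccc2noc(-c3ccc(-c4ccncc4)cc3)c2c1`, 150 nM;
compound 2 `O=C(O)c1ccc2noc(-c3ccc(N4CCCCC4)cc3)c2c1`, 240 nM;
compound 3 `O=C(O)c1ccc2noc(-c3ccc(Oc4ncc(Cl)cc4Cl)cc3)c2c1`, 650 nM.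

Compound 3 has the highest number of the three, and both of its steps are beyond the scatter: a 4.3-fold higher number from compound 1 to compound 3 (0.64 log units; beyond the scatter) and a 2.7-fold higher number from compound 2 to compound 3 (0.43 log units; beyond the scatter). Compound 4 `CC(C)NC(=O)c1ccc(-c2onc3ccc(C(=O)O)cc23)cc1` differs from compound 3 in one place: isopropylcarbamoyl in place of (3,5-dichloropyridin-2-yl)oxy on an aromatic carbon. For the measured compounds named here, no measured step uses this amide, but both measured steps show that the (3,5-dichloropyridin-2-yl)oxy group sits on the weaker side, with pyridin-4-yl and piperidin-1-yl giving lower numbers. Removing it is therefore expected to give a modest downward step, a 2.6-fold lower number from compound 3 to compound 4 (0.41 log units; beyond the scatter), of a size near those two steps. Compound 4 is estimated at 250 nM, with a range from 100 nM to 700 nM.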

Compound 4, half-maximal inhibitory concentration: 350 nM
Compound 4: the middle estimate sits 1.4-fold (0.15 log units) below what was measured, and the stated range covers the measured number.
By their numbers in this assay, from the lowest: compounds 1, 2, 4 and 3 (each within the scatter of the next, the first and the last beyond it).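

In this assay an amide with no ring can stand at this position: isopropylcarbamoyl cannot be told apart from (3,5-dichloropyridin-2-yl)oxy, with a 1.9-fold lower number from compound 3 to compound 4 (0.27 log units; within the scatter) as the step, or from piperidin-1-yl, with a 1.5-fold higher number from compound 2 to compound 4 (0.16 log units; within the scatter) as the step. For the compounds shown here, only pyridin-4-yl separates from it, with a 2.3-fold higher number from compound 1 to compound 4 (0.37 log units; beyond the scatter) as the one step beyond the scatter. No measurement shown here explains these steps.

As far as these compounds go, whether a plain primary carboxamide or a longer chain ending in an amine would come closer to pyridin-4-yl at this position stays open.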